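A second chloro on the benzyl ring of compound 2

A few compounds are considered here, and "the series" means these few. Any claim that something is new, unique, unknown or untested is made for them only; others in the source may bear on it.

For the measured compounds named here, compound 2 `Cc1noc(C)c1-c1cccc(COc2ccc3c(c2)OCC3CC(=O)O)c1` is one of three compounds measured in a functional assay on CHO cells for agonist activity at Free fatty acid receptor 1 (Homo sapiens), read by FLIPR and calcium flux; on this read-out lower numbers stand for an effect already at smaller amounts and higher numbers for an effect only at larger amounts of compound. In this assay compound 2 gives 27.5 nM. Among the three numbers it stands second highest: compound 1 `Cc1nn(C)c(C)c1-c1cccc(COc2ccc3c(c2)OCC3CC(=O)O)c1` carries a 1,3,5-trimethyl-1H-pyrazol-4-yl group where compound 2 carries the 3,5-dimethyl-1,2-oxazol-4-yl group, and compound 1 gives 104 nM, so that the step of a 3.8-fold lower number from compound 1 to compound 2 (0.58 log units; beyond the scatter) lies beyond the scatter. Compound 3 `Cc1noc(C)c1-c1cc(COc2ccc3c(c2)OCC3CC(=O)O)ccc1Cl` gives 18.6 nM, and the step of a 1.5-fold lower number from compound 2 to compound 3 (0.17 log units; within the scatter) stays within the scatter.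

Compound 4 `Cc1noc(C)c1-c1ccc(Cl)c(COc2ccc3c(c2)OCC3CC(=O)O)c1` has not yet been measured. It differs from compound 2 in one place: chloro in place of hydrogen on an aromatic carbon. The chloro group sits ortho to a large group and para to the 3,5-dimethyl-1,2-oxazol-4-yl group. Going by the values given here, the only measured step that bears on this change is a 1.5-fold lower number from compound 2 to compound 3 (0.17 log units; within the scatter), in which a chloro also replaced a hydrogen on the same ring, though not at this place, and that step was within the scatter. There is therefore no ground to expect a step beyond the scatter in this assay in either direction, while the untested place leaves some room. Compound 4 is expected to give 25 nM, with a range from 10 nM to 70 nM, which means the estimated step of a 1.1-fold lower number from compound 2 to compound 4 (0.04 log units; within the scatter).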

Compound 4, half-maximal effective concentration: 39.7 nM
For compound 4 the middle estimate is 1.6-fold (0.20 log units) below the measured one; low and high end bracket the measured number.
By their numbers in this assay, from the lowest: compounds 3, 2 and 4 (each within the scatter of the next, the first and the last beyond it); then compound 1.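

For the compounds shown here, at this place, ortho to a large group and para to a 3,5-dimethyl-1,2-oxazol-4-yl group, a chloro in place of hydrogen gives a 1.4-fold higher number from compound 2 to compound 4 (0.16 log units; within the scatter), so in this assay this second chloro position, like the one in compound 3, produces no step from compound 2 beyond the scatter. Going by these compounds alone, what the earlier compounds could not show is that the place of the chloro may still matter: compound 3 gives 18.6 nM and compound 4 gives 39.7 nM, and these two numbers lie beyond the scatter of each other even though each lies within the scatter of compound 2. Nothing at hand explains the small difference between these chloro compounds.

The compounds shown leave open whether a fluoro, a methyl or a methoxy group at this place would give a number close to that of compound 4, and whether a chloro here would give a similar step on compound 1, which carries the 1,3,5-trimethyl-1H-pyrazol-4-yl group. They also leave open what a compound carrying a chloro at both places would give in this assay.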